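Changing the aryl group on a ring amine of compound 1

The source may report more compounds than this note shows. Statements on the series, on what has been measured and on what is new or still open speak of the compounds shown alone.

Going by the values given here, compound 1 `CCCc1nc(-c2ccccc2)c(CNCCCN2CCN(c3ccc(OC)cc3)CC2)o1` holds the higher of the two numbers measured so far in an assay on HEK293 cells for inhibition of Voltage-dependent T-type calcium channel subunit alpha-1G (Homo sapiens), read by fluorescence, tested at 10 uM (on this read-out higher numbers stand for more inhibition at the one concentration tested (going by the name of the read-out) and lower numbers for less inhibition), giving 42.1%. Compound 2 `CCCc1nc(-c2ccccc2)c(CNCCN2CCN(c3cccc(OC)c3)CC2)o1` gives 40.2% in this assay, a gap within the usual scatter, so the two cannot be ranked. Compound 3 `CCCc1nc(-c2ccccc2)c(CNCCCN2CCN(c3ccccc3F)CC2)o1` is not yet measured; it differs from compound 1 as follows: 2-fluorophenyl in place of 4-methoxyphenyl on an amine nitrogen in a ring. Among the compounds with values here, no pair of measured compounds isolates such a change, so in this assay a step in either direction no larger than the scatter is expected. Compound 3 is expected to give 40%, within 20% to 60%, an expected step of a number 2.1 percentage points lower from compound 1 to compound 3 (within the scatter).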

Compound 3, a percentage reported as inhibition, at one concentration (the size of the read-out at that concentration, not a potency): 54.4%
Beside the measured number, compound 3's estimate is 14.4 percentage points below it; the range from low to high includes it.
By their numbers in this assay, from the lowest: compounds 2 and 1 (each within the scatter of the next); then compound 3.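

In this assay, placing 2-fluorophenyl instead of 4-methoxyphenyl on the amine nitrogen in the ring gives a number 12.3 percentage points higher from compound 1 to compound 3 (beyond the scatter), the first change shown here to exceed the scatter. The aryl group at this position can therefore shift the read-out, but this swap changes both the substituent and its name-given place on the phenyl ring at once. No supporting measurement explains the step.

From the compounds shown here alone, it remains open whether the gain follows the fluorine or the position it occupies. A plain phenyl, 4-fluorophenyl or 2-methoxyphenyl group on the same nitrogen would bear on that question.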